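The source may report more compounds than this note shows. Statements on the series, on what has been measured and on what is new or still open speak of the compounds shown alone.

Measured in a functional assay on SK-OV-3 cells (Homo sapiens) for inhibition, read by CCK-8 assay, with a stated time of 70 h (on this read-out higher numbers stand for weaker inhibition and lower numbers for stronger inhibition), so far:

compound 1 `Nc1ccc(COc2ccc(OCCOCCNC3CCCC3)cc2)cc1` — compound 1 gives 31700 nM
compound 2 `O=Cc1ccc(COc2ccc(OCCOCCNC3CCCC3)cc2)cc1` — compound 2 gives 45000 nM
compound 3 `Nc1cccc(COc2ccc(OCCOCCNC3CCCC3)cc2)c1` — compound 3 gives 10800 nM

Compound 3 gives the lowest number of the three; its steps to the other two, a 2.9-fold lower number from compound 1 to compound 3 (0.47 log units; beyond the scatter) and a 4.2-fold lower number from compound 2 to compound 3 (0.62 log units; beyond the scatter), both lie beyond the scatter, so on these numbers compound 3 is the strongest inhibitor of the set. Compound 4 `COC(=O)c1cccc(COc2ccc(OCCOCCNC3CCCC3)cc2)c1` is not yet measured. It differs from compound 3 in one place: methoxycarbonyl in place of amino on an aromatic carbon.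

For the measured compounds named here, the only measured step that bears on this change is a 1.4-fold higher number from compound 1 to compound 2 (0.15 log units; within the scatter), where an amino group on the same ring was likewise exchanged for a carbonyl-bearing group, at a different position; that step stayed within the scatter. Going by the values given here, no measured pair shows methoxycarbonyl itself, nor any exchange at the position where compound 4 carries it. On this single precedent, no step beyond the scatter is expected for compound 4 in this assay, with a slight lean toward a higher number. The estimate for compound 4 is 15000 nM, range 6000 nM to 40000 nM, which corresponds to the expected step of a 1.4-fold higher number from compound 3 to compound 4 (0.14 log units; within the scatter).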

Compound 4, half-maximal inhibitory concentration: 45500 nM
The estimate for compound 4 lay 3.0-fold (0.48 log units) below the measured number; the measured number lies above the stated range.
By their numbers in this assay, from the lowest: compound 3; then compounds 1, 2 and 4 (each within the scatter of the next).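

In this assay, for the compounds shown here, the exchange of amino for methoxycarbonyl at this place gives a 4.2-fold higher number from compound 3 to compound 4 (0.62 log units; beyond the scatter) and so is not neutral, unlike the one earlier exchange of amino for a carbonyl-bearing group, which stood at a different position. With methoxycarbonyl on the ring the lead of compound 3 is gone, as the series shows a 1.0-fold higher number from compound 2 to compound 4 (0.00 log units; within the scatter) and a 1.4-fold higher number from compound 1 to compound 4 (0.16 log units; within the scatter) with both steps within the scatter, so here the amino group at this place goes with the lowest number of the set. No measurement at hand explains this difference between the two exchanges.

The compounds shown leave open whether a hydroxyl or a methylamino group at this place would keep the number of compound 3. They also leave open whether a carboxylic acid there would stay level with compound 4.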